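Dibenzoylhydrazine series: branched alkyl substituents on the amide nitrogen

The compounds below may be only part of what the source reports. "The series", "measured", "known", "first", "only" and "open" are said of these compounds alone.

Measured compounds:
compound 1 `CCCCN(NC(=O)c1ccccc1)C(=O)c1ccccc1` 7080 nM
compound 2 `CC(C)CN(NC(=O)c1ccccc1)C(=O)c1ccccc1` 2880 nM

Both compounds were read in an assay on cells for agonist activity at ecdysone receptor (Bombyx mori), read by a luciferase reporter, with a stated time of 24 h; on this read-out higher numbers stand for an effect only at larger amounts of compound and lower numbers for an effect already at smaller amounts. Among the measured compounds shown here, compound 2 holds the lowest of the two numbers, the only other being compound 1, whose value sits higher by a 2.5-fold lower number from compound 1 to compound 2 (0.39 log units; beyond the scatter).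

Compound 3 `O=C(NN(CC1CCCCC1)C(=O)c1ccccc1)c1ccccc1` has not yet been measured. It differs from compound 2 in one place: cyclohexyl in place of isopropyl on a saturated chain carbon bound to an amide-type nitrogen. For the measured compounds named here, the one step that bears on this change is the move from propyl to isopropyl at the same position, which gave a 2.5-fold lower number from compound 1 to compound 2 (0.39 log units; beyond the scatter); this is the only comparison the series offers for a change on this chain carbon, and it shows a modest gain when the substituent grows and branches. Cyclohexyl goes further in the same direction, but the series gives no measured case of a ring at this position, so the direction is taken from the single step and the size kept cautious.

Compound 3 is therefore expected to show a 1.9-fold lower number from compound 2 to compound 3 (0.28 log units; within the scatter), with the estimate for compound 3 being 1500 nM and a range from 400 nM to 6000 nM.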

Compound 3, half-maximal effective concentration: 1700 nM
Beside the measured number, compound 3's estimate is 1.1-fold (0.05 log units) below it; the range from low to high includes it.
By their numbers in this assay, from the lowest: compounds 3 and 2 (each within the scatter of the next); then compound 1.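

In this assay the ring is the new finding: cyclohexyl on a saturated chain carbon bound to an amide-type nitrogen gives a 1.7-fold lower number from compound 2 to compound 3 (0.23 log units; within the scatter) and so leaves the read-out indistinguishable from that of the isopropyl compound. The first ring at this position is therefore accepted with no loss, and the further heavy atoms bring no gain that can be separated from the scatter, so the earlier step from propyl to isopropyl does not clearly extend to this larger group. Against the propyl compound the ring still gives a 4.2-fold lower number from compound 1 to compound 3 (0.62 log units; beyond the scatter) and, set beside the earlier step, this shows that both groups with a branch at this carbon stand apart from propyl, although nothing available offers an explanation for this.

Open, on these data alone, is whether a flat phenyl ring or a longer unbranched chain such as hexyl would behave like cyclohexyl at this carbon, which would separate the effect of the ring from that of size alone. Also open, as far as these compounds go, is whether this position would still accept a ring bearing an amine or a carboxylic acid, and whether a group larger than cyclohexyl would bring the number down further or push it back up.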